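Swapping the ether aryl group in a receptor modulator series

The compounds below may be only part of what the source reports. "The series", "measured", "known", "first", "only" and "open" are said of these compounds alone.

Three compounds have numbers so far:
- compound 1 `CC(C)C(=O)N1CCCn2nc(COc3ccccc3)cc21`: 59%
- compound 2 `O=C(c1cccc(F)c1)N1CCCn2nc(COc3ccccc3)cc21`: 61%
- compound 3 `CC(=O)N1CCCn2nc(COc3ccccc3F)cc21`: 60%

All three share one core and were tested in a functional assay on HEK293 cells for positive allosteric modulation of metabotropic glutamate receptor 5 (Homo sapiens), read by calcium flux; a lower number here means a smaller maximal response, a higher number a larger maximal response. Compound 3 sits second highest of the three numbers, yet its gaps to compound 1 and to compound 2 both lie within the usual scatter, so the three cannot be ranked against each other. Among the measured compounds shown here, the only step between two measured compounds, a number 2 percentage points higher from compound 1 to compound 2 (within the scatter), changes the group on the carbonyl carbon and stays within the scatter.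

Compound 4 `CC(=O)N1CCCn2nc(COc3ccncc3)cc21` differs from compound 3 elsewhere: pyridin-4-yl in place of 2-fluorophenyl on an oxygen on a saturated carbon. For the measured compounds named here, no measured step touches this part of the molecule, so no direct guide exists; the one known step only shows that the series has so far been flat. The expectation for compound 4 in this assay is therefore a change of about a number 2 percentage points lower from compound 3 to compound 4 (within the scatter), that is nothing beyond the scatter, with wide uncertainty because the aryl ether has never been varied in this way. The estimated value for compound 4 is 58%, expected to fall between 40% and 76%.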

Compound 4, largest response reached (reported as percent of maximum), in percent of the reference or control that the assay uses: < 15%
Compound 4 ended at the assay's limit; the forecaster's own chance of this, stated with the estimate: 5%; at least 43 percentage points between middle value and limit.
By their numbers in this assay, from the lowest: compounds 1, 3 and 2 (each within the scatter of the next). At a limit, below all of these: compound 4.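

This position is far less forgiving than the carbonyl side of the molecule. Among the compounds shown here, there, the only measured step gave a number 2 percentage points higher from compound 1 to compound 2 (within the scatter), whereas in this assay pyridin-4-yl in place of 2-fluorophenyl on an oxygen on a saturated carbon gave a number at least 45 percentage points lower from compound 3 to compound 4 (beyond the scatter). Compound 4 sits at a limit of the assay rather than at a measured number, so its response cannot be placed more exactly: the limit of < 15% in this assay, at which 1 of the 4 values shown sits.

This single exchange removes the fluorine and brings a ring nitrogen and a hydrogen-bond acceptor, so the compounds shown cannot separate the contributions of these changes. On these data alone, it remains open how a cyclohexyl group or a pyrimidine ring would behave on the same oxygen, and whether the same exchange would give a similar result with a benzoyl group in place of the acetyl group.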